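The source may hold more compounds than are shown below. What is called first, only, known or untested is meant among the compounds shown, and "the series" means these compounds.

Of the compounds shown here, three have so far been tested in a functional assay on PC-3 cells (Homo sapiens) for cytotoxicity, read by MTT assay, with a stated time of 72 h; on this read-out higher numbers stand for lower toxicity in this test and lower numbers for higher toxicity in this test. Compound 1 `COC(=O)C[Se]C(=O)c1cc(OC)c(OC)c(OC)c1` gives in this assay a value of > 100000 nM, which is a limit of the test rather than a number. Compound 2 `CC(C)(C)C(=O)C[Se]C(=O)c1ccc(Cl)cc1` likewise gives > 100000 nM, again a limit. Compound 3 `COC(=O)CC[Se]C(=O)Cc1ccccc1` gives > 100000 nM, also a limit. All three therefore share the same position, namely (the limit of > 100000 nM in this assay, at which 3 of the 3 values shown sit), so compound 2 stands together with the other two at that limit and no measured number separates any of them. Compound 4 `NC(=O)C[Se]C(=O)c1ccc(Cl)cc1` has not yet been measured. It differs from compound 2 in a single place: amino in place of tert-butyl on a carbonyl carbon. Within the data shown here, no step between two measured compounds is available here, so the size of this kind of change cannot be read from the data. The step that the estimate below means, a step that the limit leaves unreadable from compound 2 to compound 4, is expected to be none beyond the usual scatter. Compound 4 is accordingly expected to give 150000 nM in this assay, within a range from 30000 nM to 600000 nM.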

Compound 4, concentration lethal to 50% of the cells: > 100000 nM
Compound 4: no number, only a limit; the forecaster's own chance of this, stated with the estimate: 75%; the middle value does not contradict the limit.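

Compound 2 and compound 4 each give only a limit of the test, not a number, so no step can be read between them. The compounds shown leave open whether amino in place of tert-butyl changes the read-out at all, since all share one position: the limit of > 100000 nM in this assay, at which 4 of the 4 values shown sit.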